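Swapping a phenyl for tert-butyl on the benzyl ring

This account rests on a few compounds, and the source may have more. Where it says the series, first, only, none or still open, it means among the compounds named here.

The compounds here share one core: a bis(trifluoromethyl)phenyl sulfonamide joined through a short diamine chain to a benzyl group. Compound 1 `O=S(=O)(NCCNCc1ccc(-c2ccccc2)cc1)c1cc(C(F)(F)F)cc(C(F)(F)F)c1` was tested in a functional assay on U-87MG ATCC cells for inhibition, with U-87 MG (Homo sapiens) as the target, read by MTT assay, with a stated time of 72 h (a lower number here means a stronger inhibitor of growth, a higher number a weaker inhibitor of growth), where compound 1 gives 1400 nM. Of the three measured values this is the lowest number. Compound 3 `O=S(=O)(NCCCNCc1ccc(Br)cc1)c1cc(C(F)(F)F)cc(C(F)(F)F)c1` gives 2100 nM, and the gap between compound 1 and compound 3 lies within the scatter of repeated runs, so the two cannot be told apart. Compound 2 `COc1ccc(CNCCCNS(=O)(=O)c2cc(C(F)(F)F)cc(C(F)(F)F)c2)cc1OC` gives 3400 nM, and here the gap to compound 1 lies beyond the scatter. Within the data shown here, the only change measured in one place is a 1.6-fold lower number from compound 2 to compound 3 (0.21 log units; within the scatter), which shows that swapping one substituted benzyl ring for another left the number within the scatter.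

Compound 4 `CC(C)(C)c1ccc(CNCCNS(=O)(=O)c2cc(C(F)(F)F)cc(C(F)(F)F)c2)cc1` differs from compound 1 by tert-butyl in place of phenyl on an aromatic carbon. Among the measured compounds shown here, no measured pair covers this exact replacement; the nearest comparison, the step from compound 2 to compound 3, also changed the benzyl ring and stayed within the scatter. A step of similar size, in no clear direction, is therefore expected: a 1.1-fold higher number from compound 1 to compound 4 (0.03 log units; within the scatter). Compound 4 is estimated to give 1500 nM in this assay, with a likely range of 700 nM to 3500 nM.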

Compound 4, concentration for 50% growth inhibition: 13000 nM
Compound 4: the middle estimate sits 8.7-fold (0.94 log units) below what was measured, and the stated range ends below it.
By their numbers in this assay, from the lowest: compounds 1, 3 and 2 (each within the scatter of the next, the first and the last beyond it); then compound 4.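

Replacing phenyl with tert-butyl on this aromatic carbon, para to a large group, gives a 9.3-fold higher number from compound 1 to compound 4 (0.97 log units; beyond the scatter) in this assay. Among these compounds, that step lies beyond the scatter, whereas the one earlier step measured in one place, a 1.6-fold lower number from compound 2 to compound 3 (0.21 log units; within the scatter), lies within it, so the substituent at this position of the benzyl ring can clearly change the growth-inhibition number. Here the change goes with leaving a six-membered aromatic ring for a group with no ring and fewer heavy atoms, but no measurement given here accounts for the higher number.

The compounds shown do not separate the loss of the aromatic ring from the other differences between phenyl and tert-butyl, and a cyclohexyl group or a pyridine ring on the same carbon would help to tell these apart. On these data alone, it also remains open whether the same replacement would produce a step of similar size on the diamine chain carried by compound 3, which differs from the chain in compound 1 and compound 4.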